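A few compounds are considered here, and "the series" means these few. Any claim that something is new, unique, unknown or untested is made for them only; others in the source may bear on it.

Of the compounds shown here, three have been measured in an assay on isolated protein (Vas deferens, strain Sprague-Dawley) for antagonist activity at Alpha-1A adrenergic receptor (Rattus norvegicus), with a stated time of 20 min; on this read-out lower numbers stand for tighter binding and higher numbers for weaker binding. Compound 1, with the structure `COc1ccccc1N1CCN(CCCNC(=O)c2ccc3[nH]ccc3c2)CC1`, gives 26.3 nM. Compound 2, `COc1ccccc1N1CCN(CCCNC(=O)CCCc2c[nH]c3ccccc23)CC1`, gives 12.6 nM, and compound 3, `COc1ccc2[nH]c(C(=O)NCCCN3CCN(c4ccccc4OC)CC3)cc2c1`, gives 77.6 nM. Compound 1 therefore stands second highest of the three numbers: compound 2 lies below it by a margin beyond the usual scatter, and compound 3 lies above it by a larger margin, also beyond the scatter.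

The next compound, compound 4, has the structure `COc1ccccc1N1CCN(CCCNC(=O)c2cc3cc(O)ccc3[nH]2)CC1`. It differs from compound 1 in one place: 5-hydroxy-1H-indol-2-yl in place of 1H-indol-5-yl on a carbonyl carbon. A guide exists in compound 3, which also carries the carbonyl on the indole in the way compound 4 does and gives the highest number of the three.

The step from compound 1 to compound 4 is expected to move toward a higher number, on the order of a 2.1-fold higher number from compound 1 to compound 4 (0.32 log units; beyond the scatter), because compound 3 gives 77.6 nM with its carbonyl placed on the indole as in compound 4. Compound 4 is therefore estimated at 55 nM in this assay, within a range from 18 nM to 170 nM.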

Compound 4, dissociation constant: 55 nM
Beside the measured number, compound 4's estimate shows no gap at the digits printed; the range from low to high includes it.
By their numbers in this assay, from the lowest: compound 2; then compound 1; then compounds 4 and 3 (each within the scatter of the next).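

In this assay, 5-hydroxy-1H-indol-2-yl in place of 1H-indol-5-yl on the carbonyl carbon gives a 2.1-fold higher number from compound 1 to compound 4 (0.32 log units; beyond the scatter) and counts as a modest step, so this place responds to the swap without a large change in the number. Hydrogen in place of methyl on the oxygen on the aromatic ring gives a 1.4-fold lower number from compound 3 to compound 4 (0.15 log units; within the scatter) and so cannot be told apart from repeat scatter, which means compound 3 and compound 4 read alike here. Still open, on these data alone, is how much of the first step belongs to the hydroxy and how much to going from 1H-indol-5-yl to 1H-indol-2-yl, which plain 1H-indol-2-yl on the same carbonyl carbon would separate, and whether an amine in place of the hydroxy would read the same. Nothing at hand gives a reason for either step.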